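Chloro for methyl on the pendant ring of three isatin-type thiosemicarbazones

This account rests on a few compounds, and the source may have more. Where it says the series, first, only, none or still open, it means among the compounds named here.

Measured compounds:
compound 1, `O=C1Nc2cc(Cl)c(F)cc2/C1=N/NC(=S)Nc1ccc(Cl)cc1`: 43000 nM
compound 2, `Cc1ccc(NC(=S)N/N=C2\C(=O)Nc3cc(Cl)c(F)cc32)cc1`: 112000 nM
compound 3, `Cc1ccc(CN2C(=O)/C(=N\NC(=S)Nc3ccc(Cl)cc3)c3cc(Cl)ccc32)cc1`: 5800 nM

The three compounds were run in a functional assay on MOLT-4 cells (Homo sapiens), with a stated time of 72 h; on this read-out higher numbers stand for weaker inhibition and lower numbers for stronger inhibition. Compound 2 is the weakest of the three measured, and compound 1 stands next with a lower number. The two differ in one place: chloro in place of methyl on an aromatic carbon. That single exchange produced a 2.6-fold lower number from compound 2 to compound 1 (0.42 log units; beyond the scatter), a step beyond the usual scatter.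

Compound 3 carries a different core, and the difference between the core of compound 3 and the core of compound 2 is not broken down here. In this assay compound 3 gives the lowest number of the set, some way beyond the scatter from both compound 1 and compound 2.

Compound 4, `O=C1/C(=N\NC(=S)Nc2ccc(Cl)cc2)c2cc(Cl)ccc2N1Cc1ccc(Cl)cc1`, has not yet been measured. It differs from compound 3 in one place: chloro in place of methyl on an aromatic carbon. The place is the same in its printed words as for the earlier pair, although read one bond further out it is 4-methylbenzyl to 4-chlorobenzyl here rather than (4-methylphenyl)amino to (4-chlorophenyl)amino, so the two changes are of the same kind on differently attached rings. On the strength of the step of a 2.6-fold lower number from compound 2 to compound 1 (0.42 log units; beyond the scatter), the change is expected to lower the number again, by a modest amount, giving an estimated 1.7-fold lower number from compound 3 to compound 4 (0.22 log units; within the scatter). Compound 4 is therefore estimated at 3500 nM in this assay, with a likely range from 1500 nM to 9000 nM.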

Compound 4, half-maximal inhibitory concentration: 58000 nM
Compound 4: the middle estimate sits 17-fold (1.22 log units) below what was measured, and the stated range ends below it.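

In this assay, chloro in place of methyl did not carry over from one core to the other in this series: on the core of compound 3, where the exchange reads 4-methylbenzyl to 4-chlorobenzyl, it gave a 10-fold higher number from compound 3 to compound 4 (1.00 log units; beyond the scatter), the opposite direction to the earlier pair. The two steps cannot be treated as one repeated effect of the exchange, since they part by more than repeat measurements would allow: the same change on two cores in this assay, a 2.6-fold lower number (0.42 log units; beyond the scatter) from compound 2 to compound 1 and a 10-fold higher number (1.00 log units; beyond the scatter) from compound 3 to compound 4, 26-fold (1.42 log units) apart, beyond the scatter of two such steps. For the compounds shown here, this shows that, across these two pairs, the sign of the step depends on its setting, but with only one pair on each core it does not show which feature of that setting matters, whether the rest of the core or the way the ring is attached, and it gives no rule for any third core.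

The compounds shown leave open whether 4-methylphenyl to 4-chlorophenyl on the core of compound 3, or 4-methylbenzyl to 4-chlorobenzyl on the core of compound 1, would follow the step seen on that core or the step seen on that attachment. They also leave open how a methoxy group or an amine in the same place would read, and so whether the reversal is particular to methyl and chloro.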